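This account rests on a few compounds, and the source may have more. Where it says the series, first, only, none or still open, it means among the compounds named here.

Measured compounds:
compound 1, `O=C1CCCc2[nH]c(=O)c(C(=O)c3ccccc3)cc21`, gives 6% in an assay on isolated protein for inhibition of 3',5'-cyclic-AMP phosphodiesterase 4A (Cavia porcellus), read by cAMP accumulation, tested at 100 uM; on this read-out higher numbers stand for a stronger effect at the one concentration tested and lower numbers for a weaker effect
compound 2, `O=C1CC(c2ccccc2)Cc2[nH]c(=O)c(C(=O)c3ccccc3)cc21`, gives 7.8% in this assay

On the numbers shown, compound 1 sits at the bottom of the two, yet the step of a number 1.8 percentage points higher from compound 1 to compound 2 (within the scatter) lies within the scatter, so compound 1 and compound 2 cannot be told apart on this read-out. Compound 3, `CC(C)(C)C(=O)c1cc2c([nH]c1=O)CCCC2=O`, has not yet been measured in this assay. It differs from compound 1 by tert-butyl in place of phenyl on a carbonyl carbon. Among the compounds with values here, the only measured step concerns phenyl in place of hydrogen on a saturated ring carbon, a different place from the carbonyl carbon changed here, so no measured step bears directly on this change. Both measured numbers are small and close together, and nothing shown points to a change beyond the scatter. For compound 3 the expected step is no change at the digits printed from compound 1 to compound 3 (within the scatter). Compound 3 is therefore estimated at 6%, within -5% to 17%.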

Compound 3, a percentage reported as inhibition, at one concentration (the size of the read-out at that concentration, not a potency): 6.6%
Compound 3: middle estimate off by 0.6 percentage points, on the low side; the range from low to high includes it.
By their numbers in this assay, from the lowest: compounds 1, 3 and 2 (each within the scatter of the next).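

Putting tert-butyl in place of phenyl on a carbonyl carbon gives a number 0.6 percentage points higher from compound 1 to compound 3 (within the scatter) in this assay. Within the data shown here, this is the first measured change at this carbonyl carbon, and it shows that a group with no ring, with 4 heavy atoms rather than 6, cannot be told apart from phenyl on this read-out. No evidence is available that would explain this result.

The compounds shown leave open whether any group on this carbonyl carbon can move the number beyond the scatter, for instance an amine, a carboxylic acid or a longer chain. They also leave open whether tert-butyl here would read the same with phenyl on the saturated ring carbon, as in compound 2.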